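Removing a Chloro Group: Effect on Cell Potency

The compounds below may be only part of what the source reports. "The series", "measured", "known", "first", "only" and "open" are said of these compounds alone.

compound 1 `O=C(Nc1cc(F)cc(F)c1)c1ccc2cccnc2c1O` — 510 nM
compound 2 `N#Cc1ccc(NC(=O)c2ccc(Br)cc2O)c(Cl)c1` — 730 nM

In a functional assay on HL-60 cells (Homo sapiens) for cytotoxicity, read by luminescence and CellTiter-Glo, with a stated time of 3 days (a lower number here means a stronger inhibitor, a higher number a weaker inhibitor), compound 2 gives 730 nM, the larger of the two numbers, while compound 1 gives 510 nM; the gap between them lies within the scatter, so the two compounds cannot be told apart on these data. Compound 3 `N#Cc1ccc(NC(=O)c2ccc(Br)cc2O)cc1` has not yet been measured. It differs from compound 2 in one place: hydrogen in place of chloro on an aromatic carbon. Within the data shown here, no measured pair shows this exact change, so its effect has to be judged from the change itself. A chloro group is one heavy atom, and the rest of the molecule stays as it is. The step from compound 2 to compound 3 in this assay is therefore expected to be small, perhaps toward a somewhat higher number, or nothing beyond the scatter. For compound 3 the expected value in this assay is 1000 nM, with a range from 300 nM to 3500 nM. This estimate means an expected step of a 1.4-fold higher number from compound 2 to compound 3 (0.14 log units; within the scatter).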

Compound 3, half-maximal inhibitory concentration: 1210 nM
The estimate for compound 3 lay 1.2-fold (0.08 log units) below the measured number; the range from low to high includes it.
By their numbers in this assay, from the lowest: compounds 1, 2 and 3 (each within the scatter of the next, the first and the last beyond it).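

Hydrogen in place of chloro on the aromatic carbon ortho to a large group and meta to a cyano group gives a 1.7-fold higher number from compound 2 to compound 3 (0.22 log units; within the scatter) in this assay and is the first direct reading at this position, since compound 1 differs from compound 2 in more than one place. Losing this one heavy atom leaves compound 2 and compound 3 indistinguishable in this measurement, so the chloro group shows no measurable contribution here, though a small one could lie hidden in the scatter. No measurement shown here offers an explanation for this result.

From the compounds shown here alone, whether an amine, a methoxy group or a carboxylic acid on this same carbon would also leave the number within the scatter remains open. A single pair also cannot show whether this change would have the same small size on a different core.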